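The compounds below may be only part of what the source reports. "The series", "measured", "known", "first", "only" and "open" are said of these compounds alone.

Going by the values given here, in a physicochemical assay for lipophilicity (on this read-out lower numbers stand for lower lipophilicity and higher numbers for higher lipophilicity), compound 1 `O=S(=O)(Nc1nccs1)c1ccc2c(c1)OCC[C@H]2c1ccc(C(F)(F)F)cc1-n1ccnn1` gives 2.3, the lower of the two numbers so far. Compound 2 `Cn1nccc1-c1cc(C(F)(F)F)ccc1[C@H]1CCOc2cc(S(=O)(=O)Nc3ccc(F)cn3)ccc21` gives 3.8, a higher number, and the gap between these two compounds lies outside the usual scatter. Compound 3 `Cn1nccc1-c1cc(C(F)(F)F)ccc1[C@@H]1CCOc2cc(S(=O)(=O)Nc3nccs3)ccc21` is not yet measured and differs from compound 1 by 1-methyl-1H-pyrazol-5-yl in place of 1H-1,2,3-triazol-1-yl on an aromatic carbon, with 1-methyl-1H-pyrazol-5-yl in place of 1H-1,2,3-triazol-1-yl on an aromatic carbon. Among the compounds with values here, no measured step isolates this change. Compound 2 also carries 1-methyl-1H-pyrazol-5-yl and reads 3.8, so a rise beyond the scatter is expected. The expected step is a number 0.70 log units higher from compound 1 to compound 3 (beyond the scatter). For compound 3 the estimated value is 3, with an expected range of 2.6 to 3.5.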

Compound 3, distribution coefficient: 2.2
Compound 3: the middle estimate sits 0.80 log units above what was measured, and the stated range ends above it.
By their numbers in this assay, from the lowest: compounds 3 and 1 (each within the scatter of the next); then compound 2.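

On the aromatic carbon ortho to a large group and meta to a trifluoromethyl group, 1-methyl-1H-pyrazol-5-yl in place of 1H-1,2,3-triazol-1-yl gives a number 0.10 log units lower from compound 1 to compound 3 (within the scatter) in this assay on the core of compound 1. Going by these compounds alone, this is the first isolated reading at this position, and the exchange of these two rings leaves the number within the scatter. No measurement at hand accounts for this outcome.

Still open, going by these compounds, is how this assay responds to an amine or a carboxylic acid on this carbon. On these data alone, whether this exchange reads the same on a core with a different remaining substitution is also open.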